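The source may hold more compounds than are shown below. What is called first, only, known or untested is meant among the compounds shown, and "the series" means these compounds.

Measured compounds:
compound 1, `O=C(CCC(=O)OCCCCCCSc1ccc([N+](=O)[O-])c2nonc12)Nc1cccc(Cl)c1`, 2890 nM
compound 2, `O=C(CCC(=O)OCCCCCCSc1ccc([N+](=O)[O-])c2nonc12)Nc1ccc(Br)cc1`, 2710 nM

Both were tested in a functional assay on 143B cells (Homo sapiens) for inhibition, read by MTT assay, with a stated time of 72 h; on this read-out higher numbers stand for weaker inhibition and lower numbers for stronger inhibition. Compound 2 holds the lowest of the two numbers, but its neighbour compound 1 sits only a 1.1-fold lower number from compound 1 to compound 2 (0.03 log units; within the scatter) away, so the two cannot be told apart. Compound 3, `O=C(CCC(=O)N1CCOCC1)OCCCCCCSc1ccc([N+](=O)[O-])c2nonc12`, has not yet been measured. It differs from compound 2 in one place: morpholin-4-yl in place of (4-bromophenyl)amino on a carbonyl carbon. Among the compounds with values here, the only measured step swaps one halogenated phenyl group for another on the amide-type nitrogen and changes nothing beyond the scatter; it says nothing about exchanging the (4-bromophenyl)amino group for morpholin-4-yl on the carbonyl carbon, so no measured step bears on this change. With no guide, compound 3 is expected near the two measured numbers, with wide uncertainty leaning toward a higher number, that is a 1.7-fold higher number from compound 2 to compound 3 (0.22 log units; within the scatter). The estimate for compound 3 is 4500 nM, between 1500 nM and 14000 nM.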

Compound 3, half-maximal inhibitory concentration: 1530 nM
For compound 3 the middle estimate is 2.9-fold (0.47 log units) above the measured one, within the range that was stated.
By their numbers in this assay, from the lowest: compounds 3, 2 and 1 (each within the scatter of the next).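

In this assay, morpholin-4-yl on the carbonyl carbon stands in for (4-bromophenyl)amino (a 1.8-fold lower number from compound 2 to compound 3 (0.25 log units; within the scatter)) and for (3-chlorophenyl)amino (a 1.9-fold lower number from compound 1 to compound 3 (0.28 log units; within the scatter)), so all three compounds lie within the scatter of one another. Within the data shown here, the earlier pair had exchanged only one halogenated phenyl group for another, whereas these steps show that neither the aromatic ring nor the amide hydrogen is needed here for a value in this range: a six-membered non-aromatic ring with no hydrogen-bond donor serves as well. Nothing available accounts for this result.

The compounds shown leave open how a piperazine, a primary amine or a carboxylic acid would read on this carbonyl carbon. They also leave open whether a longer chain in place of the hexyl chain would shift the values.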